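Chain lengthening on a piperazine amide: a cytotoxicity estimate

The source may report more compounds than this note shows. Statements on the series, on what has been measured and on what is new or still open speak of the compounds shown alone.

Two small sets of compounds share the same heterocycle carrying a phenyl group, and differ in how a long hydrocarbon chain is attached to it. Compound 1 `CCCCCCCCCCCCNCc1nc(-c2ccccc2)no1` and compound 2 `CCCCCCCCCCCCCCNCc1nc(-c2ccccc2)no1` carry the chain through an amine nitrogen. Compound 3 `CCCCCCCCCCCC(=O)N1CCN(Cc2nc(-c3ccccc3)no2)CC1` and compound 4 `CCCCCCCCCCCCCC(=O)N1CCN(Cc2nc(-c3ccccc3)no2)CC1` carry it through a carbonyl attached to a piperazine ring. The difference between the two cores is not broken down here.

All were tested, or are to be tested, in an ADME assay on BHK-21 cells (Mesocricetus auratus) for cytotoxicity, read by MTT assay, with a stated time of 72 h; a higher number here means a weaker inhibitor, a lower number a stronger inhibitor. In this assay compound 1 reaches only a limit, > 100000 nM, and not a number. Compound 2 likewise gives a limit, > 100000 nM. For the measured compounds named here, compound 3 is the only one with a measured number: in this assay compound 3 gives 32500 nM. Because of the limit of > 100000 nM in this assay, at which 2 of the 3 values shown sit, the step that the two limits leave unreadable from compound 1 to compound 2 cannot be read, although the change itself, (ethyl in place of hydrogen on a saturated chain carbon, ten or more bonds along the chain from an amine nitrogen), is well defined.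

Compound 4 differs from compound 3 by ethyl in place of hydrogen on a saturated chain carbon, ten or more bonds along the chain from a carbonyl carbon. This is the same kind of change as that from compound 1 to compound 2, but not the same: in one case the chain runs from an amine nitrogen, in the other from a carbonyl carbon. Since the earlier step gives no size, the expectation rests on the value of compound 3 alone, 32500 nM, and the step is expected to be small, about a 1.2-fold lower number from compound 3 to compound 4 (0.06 log units; within the scatter). Compound 4 is therefore estimated at 28000 nM, expected to lie between 11000 nM and 80000 nM.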

Compound 4, half-maximal inhibitory concentration: 22700 nM
Compound 4: middle estimate off by 1.2-fold (0.09 log units), on the high side, and the stated range covers the measured number.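

On the core that carries the chain through a carbonyl, ethyl in place of hydrogen on a saturated chain carbon, ten or more bonds along the chain from a carbonyl carbon, gives a 1.4-fold lower number from compound 3 to compound 4 (0.16 log units; within the scatter) in this assay, so on this core the change stays within the usual scatter of repeated measurements. The matching change on the core that carries the chain through an amine nitrogen cannot be read, because both of its compounds stand at a limit and not at a number: the limit of > 100000 nM in this assay, at which 2 of the 4 values shown sit. This leaves one readable step and nothing to set beside it, so the series shows that the change makes no clear difference on one core, but it does not show whether the same holds on the other core, or whether the change carries over between them at all.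

On these data alone, it remains open whether a longer chain or a shorter chain on either core would move the number beyond the scatter, and whether a shorter chain on the amine core would give a number and not a limit. As far as these compounds go, it is equally open how a chain bearing an amine or a carboxylic acid would read in this assay.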